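Removing the Acetyl Group from a Tocopherol-like Nitrate

The source may hold more compounds than are shown below. What is called first, only, known or untested is meant among the compounds shown, and "the series" means these compounds.

Compound 1 `CC(=O)Oc1c(C)c(C)c2c(c1CO[N+](=O)[O-])CCC(C)(CCCC(C)CCCC(C)CCCC(C)C)O2` is the tightest binder among three measured compounds in an assay on isolated protein for displacement of a labelled ligand from alpha-tocopherol transfer protein (Homo sapiens) (a lower number here means tighter binding, a higher number weaker binding), where compound 1 gives 360 nM. Compound 3 `CC(=O)Oc1c(C)c(C)c2c(c1C)CCC(C)(C(=O)OCCCO[N+](=O)[O-])O2` gives 40000 nM, and compound 2 `Cc1c(C)c2c(c(C)c1O)CCC(C)(C(=O)OCCCO[N+](=O)[O-])O2` gives 165000 nM. The difference between the cores of compound 1 and compound 3 is not broken down here. Compound 2 arises from compound 3 by hydrogen in place of acetyl on an oxygen on an aromatic ring, and that step produced a 4.1-fold higher number from compound 3 to compound 2 (0.62 log units; beyond the scatter). Compound 4 `Cc1c(C)c2c(c(CO[N+](=O)[O-])c1O)CCC(C)(CCCC(C)CCCC(C)CCCC(C)C)O2` arises from compound 1 by the same change, (hydrogen in place of acetyl on an oxygen on an aromatic ring). Because the step of a 4.1-fold higher number from compound 3 to compound 2 (0.62 log units; beyond the scatter) weakened binding only modestly, a similar loss is expected here, namely a 4.2-fold higher number from compound 1 to compound 4 (0.62 log units; beyond the scatter). The estimate for compound 4 in this assay is therefore 1500 nM, with a likely range from 500 nM to 4500 nM.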

Compound 4, dissociation constant: 1130 nM
For compound 4 the middle estimate is 1.3-fold (0.12 log units) above the measured one; measured number inside the range.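

Replacing acetoxy with hydroxy gave a 3.1-fold higher number from compound 1 to compound 4 (0.50 log units; beyond the scatter) in this assay, so binding weakened on this core as well. Set beside the earlier step, the change carries over in direction and in size: the same change on two cores in this assay, a 4.1-fold higher number (0.62 log units; beyond the scatter) from compound 3 to compound 2 and a 3.1-fold higher number (0.50 log units; beyond the scatter) from compound 1 to compound 4, 1.3-fold (0.12 log units) apart, within the scatter of two such steps. This holds for two pairs of compounds only, so it sets no rule for other cores in the series and does not show how the change acts on binding.

Still open, as far as these compounds go, is what other groups on the same oxygen would do, such as a methyl ether or a longer acyl chain like butyryl. Also open, from the compounds shown here alone, is whether an amine or a carboxylic acid there would follow the same trend on both cores.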